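The source may hold more compounds than are shown below. What is called first, only, known or untested is meant among the compounds shown, and "the series" means these compounds.

Measured compounds:
compound 1, `COc1ccc(N(C)c2ncnc3c2ncn3Cc2cc(OC)cc(OC)c2)cc1` — in a functional assay on K562 cells (Homo sapiens) for antiproliferative activity, read by MTT assay, with a stated time of 48 h (on this read-out lower numbers stand for stronger inhibition of growth and higher numbers for weaker inhibition of growth), compound 1 gives 42000 nM
compound 2, `COc1ccc(N(C)c2ncnc3c2ncn3Cc2cc(OC)c(OC)c(OC)c2)cc1` — in this assay compound 2 gives > 100000 nM, which is a limit of this assay and not a number
compound 3, `COc1ccc(Cn2cnc3c(N(C)c4ccc(OC)cc4)nc(Cl)nc32)cc1` — in this assay compound 3 gives > 100000 nM, which is a limit of this assay and not a number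

The change from compound 1 to compound 2 is methoxy in place of hydrogen on an aromatic carbon. It made an at least 2.3-fold higher number from compound 1 to compound 2 (0.37 log units; beyond the scatter). Its size is bounded by the limit of > 100000 nM in this assay, at which 2 of the 3 values shown sit.

Compound 4, `COc1ccc(N(C)c2nc(Cl)nc3c2ncn3Cc2ccc(OC)c(OC)c2)cc1`, is not yet measured. The change from compound 3 to compound 4 is methoxy in place of hydrogen on an aromatic carbon; it is the same kind of change, though here the entering group sits ortho to a methoxy group and meta to a large group, whereas in compound 2 it sits ortho to two methoxy groups and para to a large group. The difference between the core of compound 3 and the core of compound 1 is not broken down here.

Within the data shown here, compound 3 already sits at a limit of this assay, and the one measured instance of this kind of change raised the number, so compound 4 is expected to remain at or beyond that limit, giving an expected step that the limit leaves unreadable from compound 3 to compound 4. The expected value for compound 4 is 150000 nM, within 60000 nM to 500000 nM.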

Compound 4, concentration for 50% growth inhibition: 27000 nM
Compound 4: middle estimate off by 5.6-fold (0.74 log units), on the high side; measured number below the stated range.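

The new step is an at least 3.7-fold lower number from compound 3 to compound 4 (0.56 log units; beyond the scatter) in this assay, so the direction of the methoxy change did not carry from one core to the other in these two pairs: the same change on two cores in this assay, an at least 2.3-fold higher number (0.37 log units; beyond the scatter) from compound 1 to compound 2 and an at least 3.7-fold lower number (0.56 log units; beyond the scatter) from compound 3 to compound 4, at least 8.8-fold (0.94 log units) apart, beyond the scatter of two such steps Each step has one end at a limit, so its size is only a bound: the limit of > 100000 nM in this assay, at which 2 of the 4 values shown sit. With one pair per core, and with the entering methoxy ortho to a methoxy group and meta to a large group in compound 4 but in a different place in compound 2, these data do not separate the effect of the core from that of the place.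

Still open, from the compounds shown here alone, is whether 4-methoxyphenyl to 3,4-dimethoxyphenyl gives a lower number on the core of compound 1 as well. Also open, going by these compounds, is how an amine or a carboxylic acid in place of the entering methoxy would read on the core of compound 3.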